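Swapping Oxygen for Sulfur on a Shared Diamine Core

The source may report more compounds than this note shows. Statements on the series, on what has been measured and on what is new or still open speak of the compounds shown alone.

The three measured compounds share one core and differ only in the group attached to it through an oxygen or a sulfur atom. In a functional assay on MDA-MB-435 cells (Homo sapiens) for inhibition, read by sulforhodamine B assay, with a stated time of 48 h (on this read-out lower numbers stand for stronger inhibition of growth and higher numbers for weaker inhibition of growth), compound 3, `Nc1cc(N)c2nc(-c3ccccc3)c(Oc3ccc(F)cc3)nc2c1`, gives 32400 nM. Compound 2, `Nc1cc(N)c2nc(-c3ccccc3)c(Sc3ccc(Cl)c(Cl)c3)nc2c1`, gives 60300 nM in this assay. Compound 1, `COc1ccc(Sc2nc3cc(N)cc(N)c3nc2-c2ccccc2)cc1`, reaches only the limit of < 100000 nM in this assay, so it is a limit and not a number. Compound 3 sits at the low end of the two real numbers, yet the step of a 1.9-fold lower number from compound 2 to compound 3 (0.27 log units; within the scatter) stays within the scatter, so compounds 2 and 3 cannot be told apart. The steps from compound 1 are unreadable, a step that the limit leaves unreadable from compound 1 to compound 2 and a step that the limit leaves unreadable from compound 1 to compound 3, because of the limit of < 100000 nM in this assay, at which 1 of the 3 values shown sits.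

Compound 4, `Nc1cc(N)c2nc(-c3ccccc3)c(Sc3ccc(F)cc3)nc2c1`, is not yet measured. It differs from compound 3 in one place: (4-fluorophenyl)sulfanyl in place of 4-fluorophenoxy on an aromatic carbon. For the measured compounds named here, no measured step isolates this exchange of oxygen for sulfur: the step from compound 2 to compound 3 changed the linking atom and the attached ring together and stayed within the scatter, and the steps from compound 1 cannot be read. The change is therefore expected to give a step of about a 1.1-fold higher number from compound 3 to compound 4 (0.03 log units; within the scatter), nothing beyond the scatter. Compound 4 is estimated at 35000 nM, with a likely range from 12000 nM to 100000 nM.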

Compound 4, concentration for total growth inhibition: 33100 nM
Compound 4: the middle estimate sits 1.1-fold (0.02 log units) above what was measured, and the stated range covers the measured number.
By their numbers in this assay, from the lowest: compounds 3, 4 and 2 (each within the scatter of the next).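

For the compounds shown here, with a 1.0-fold higher number from compound 3 to compound 4 (0.01 log units; within the scatter), oxygen gives way to sulfur as the linking atom while the 4-fluorophenyl ring stays the same, so this is the first readable step that isolates the linking atom at this aromatic carbon, and it shows no difference that can be told from the scatter. With a 1.8-fold lower number from compound 2 to compound 4 (0.26 log units; within the scatter), the sulfur stays in place and only the attached ring changes, with 4-fluorophenyl in place of 3,4-dichlorophenyl, and this step also stays within the scatter, so neither single change, taken alone, separates the compounds in this assay. Compound 1 carries a limit and not a number, so its step to compound 4 cannot be read, and the effect of fluoro in place of methoxy on the attached ring stays unknown: the limit of < 100000 nM in this assay, at which 1 of the 4 values shown sits.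

The compounds shown leave open what happens when the linking oxygen or sulfur is replaced by an amine nitrogen, or when the attached ring is replaced by a longer alkyl chain. They also leave open whether a carboxylic acid on the attached ring would give a step beyond the scatter.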